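Solubility notes: lactam in place of imidazolylmethyl

The compounds below may be only part of what the source reports. "The series", "measured", "known", "first", "only" and "open" are said of these compounds alone.

compound 1 `CC(C)C(Cc1ncc[nH]1)c1ccc(-c2ccc3cccc(F)c3c2)[nH]c1=O` — 22100 nM
compound 2 `CCn1ncc2c(F)cc(-c3ccc(C(CC)(CC)c4nnc[nH]4)c(=O)[nH]3)cc21` — 35500 nM

In a physicochemical assay for solubility, in phosphate buffer, measured as kinetic solubility (on this read-out lower numbers stand for lower solubility and higher numbers for higher solubility), compound 1 stands at 22100 nM. Going by the values given here, the only other measured compound, compound 2, gives 35500 nM in this assay, and the gap between the two lies within the usual scatter, so neither can be set apart from the other.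

Compound 3 `CC(C)C(c1ccc(-c2ccc3cccc(F)c3c2)[nH]c1=O)N1CCCCC1=O` is not yet measured. It differs from compound 1 by 2-oxopiperidin-1-yl in place of (1H-imidazol-2-yl)methyl on a saturated chain carbon bound to an aromatic carbon and a saturated chain carbon. Among the compounds with values here, no step between measured compounds covers such a change, so no precedent exists. A modest step downward from compound 1 is expected, a 1.5-fold lower number from compound 1 to compound 3 (0.17 log units; within the scatter), possibly not beyond the scatter. Compound 3 is estimated at 15000 nM, with a range of 5000 nM to 45000 nM.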

Compound 3, solubility: 23100 nM
Compound 3: middle estimate off by 1.5-fold (0.19 log units), on the low side; measured number inside the range.
By their numbers in this assay, from the lowest: compounds 1, 3 and 2 (each within the scatter of the next).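

On a saturated chain carbon bound to an aromatic carbon and a saturated chain carbon, 2-oxopiperidin-1-yl in place of (1H-imidazol-2-yl)methyl gives a 1.0-fold higher number from compound 1 to compound 3 (0.02 log units; within the scatter) in this assay. This position therefore accepts the exchange of a five-membered aromatic ring for a six-membered non-aromatic ring, and the loss of a hydrogen-bond donor, without a step beyond the scatter. No supporting data bear on this result.

From the compounds shown here alone, whether a basic amine or a carboxylic acid on this carbon would give a step beyond the scatter remains open.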